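Removing the Ester Group of Compound 3

A few compounds are considered here, and "the series" means these few. Any claim that something is new, unique, unknown or untested is made for them only; others in the source may bear on it.

Three compounds that carry a free thiol on a short chain have been tested in a functional assay, with a stated time of 30 min, tested at 50 uM; a lower number here means a weaker effect, a higher number a stronger effect of the compound at the concentration tested. Compound 1 `CCOC(=O)C(CS)NC(=O)c1cc(C(C)(C)C)c(O)c(C(C)(C)C)c1` gives 23%. Compound 2 `CCOC(=O)C(CS)NC(=O)C1(C)CCc2c(C)c(O)c(C)c(C)c2O1` gives 61%. Compound 3 `CCOC(=O)C(CS)NC(=O)/C=C/c1ccccc1` gives 27%.

Among these three values compound 3 holds the second highest. Its nearest neighbour is compound 1, whose value lies within the usual scatter of its own, so the two cannot be told apart. The furthest is compound 2, whose higher value lies beyond the scatter.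

Compound 4 `O=C(/C=C/c1ccccc1)NCCS` has not yet been measured. It differs from compound 3 in one place: hydrogen in place of ethoxycarbonyl on a saturated chain carbon bound to an amide-type nitrogen and a saturated chain carbon. Going by the values given here, no pair of measured compounds shows what such a change does in this assay, so the expectation rests on the change itself and on the spread of the three known values. The step of a number 2 percentage points lower from compound 3 to compound 4 (within the scatter) is expected to be small, not beyond the scatter in either direction. Compound 4 is therefore estimated to give 25%, with a range from 8% to 45%.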

Compound 4, a percentage reported as activity, at one concentration (the size of the read-out at that concentration, not a potency): 31%
Compound 4: middle estimate off by 6 percentage points, on the low side; the measured number falls inside the stated range.
By their numbers in this assay, from the lowest: compounds 1, 3 and 4 (each within the scatter of the next); then compound 2.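

In this assay, hydrogen in place of ethoxycarbonyl on this saturated chain carbon gives a number 4 percentage points higher from compound 3 to compound 4 (within the scatter), so this change cannot be told apart from no change at all. Going by these compounds alone, for the first time, a matched pair shows that, in this one setting, the ethoxycarbonyl group can be removed without a shift that rises above the scatter. No measurement shown here explains this result or says what the group does at this position.

As far as these compounds go, whether a carboxylic acid, an amine or a longer chain on the same carbon would also leave the read-out unchanged remains open. This step also rests on a single pair, so the same replacement on the cores of compound 1 and compound 2 could give a different result.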